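Replacing a Dimethoxyphenyl with a Fluoro-Methoxyphenyl

A few compounds are considered here, and "the series" means these few. Any claim that something is new, unique, unknown or untested is made for them only; others in the source may bear on it.

Measured compounds and their values:
- compound 1, `COc1cccc(OC)c1N1C(=O)CSC1c1cccc(C(=O)NCCCCc2ccccc2)c1`: 41%
- compound 3, `CCOc1ccccc1N1C(=O)C(C)SC1c1cccc(C(=O)NCCCCc2ccccc2)c1`: 37%
- compound 2, `O=C(NCCCCc1ccccc1)c1cccc(C2OCC(=O)N2c2cccc(F)c2)c1`: 25%

In a functional assay on U2OS cells (Homo sapiens) for inhibition, read by CCK-8 assay, with a stated time of 72 h, tested at 1 uM (on this read-out higher numbers stand for more inhibition at the one concentration tested (going by the name of the read-out) and lower numbers for less inhibition), compound 1 gives 41%, the highest of the three numbers. Compound 3 gives 37%, which sits within the scatter of compound 1, so the two cannot be told apart. Compound 2 gives 25%, beyond the scatter below compound 1.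

Compound 4, `COc1ccc(F)cc1N1C(=O)CSC1c1cccc(C(=O)NCCCCc2ccccc2)c1`, differs from compound 1 in one place: 5-fluoro-2-methoxyphenyl in place of 2,6-dimethoxyphenyl on an amide-type nitrogen in a ring. Among the compounds with values here, no measured pair shows the effect of such a swap, so the expected step in this assay is small, with no clear direction beyond the scatter. Compound 4 is therefore expected to give about 36%, in the range 22% to 50%, which means an expected step of a number 5 percentage points lower from compound 1 to compound 4 (within the scatter).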

Compound 4, a percentage reported as inhibition, at one concentration (the size of the read-out at that concentration, not a potency): 32%
Compound 4: the middle estimate sits 4 percentage points above what was measured; low and high end bracket the measured number.
By their numbers in this assay, from the lowest: compounds 2, 4, 3 and 1 (each within the scatter of the next, the first and the last beyond it).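

Putting 5-fluoro-2-methoxyphenyl in place of 2,6-dimethoxyphenyl on the amide-type nitrogen in a ring gives a number 9 percentage points lower from compound 1 to compound 4 (within the scatter). This first one-place comparison shows that, in this assay, this position accepts this change of aryl group without a shift that can be told from the scatter. No measurement here bears on the reason for this result. Still open, going by these compounds, is whether a phenyl carrying an amine or a carboxylic acid at this position would move the number beyond the scatter in either direction.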